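Methoxy for fluoro on the carboxyphenyl ring

This account rests on a few compounds, and the source may have more. Where it says the series, first, only, none or still open, it means among the compounds named here.

Working notes on the series sharing the core of compound 1 `Cc1c(OC[C@@H](C)COc2ccc(C(=O)O)cc2F)ccc(C(=O)CC(C)(C)C)c1O`. In an assay for positive allosteric modulation of metabotropic glutamate receptor 3 (Rattus norvegicus) (on this read-out higher numbers stand for an effect only at larger amounts of compound and lower numbers for an effect already at smaller amounts), compound 1 gives 1300 nM. Compound 2 `Cc1c(OC[C@@H](C)COc2ccc(C(=O)O)cc2Cl)ccc(C(=O)CC(C)(C)C)c1O` gives 1650 nM in this assay, and compound 3 `Cc1c(OC[C@@H](C)COc2ccc(C(=O)O)c(F)c2)ccc(C(=O)CC(C)(C)C)c1O` gives 1090 nM. The three numbers sit within the scatter of one another: a 1.3-fold higher number from compound 1 to compound 2 (0.10 log units; within the scatter), a 1.2-fold lower number from compound 1 to compound 3 (0.08 log units; within the scatter) and a 1.5-fold lower number from compound 2 to compound 3 (0.18 log units; within the scatter), so compound 3 is not set apart from compound 1 or compound 2 in this assay.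

Compound 4 `COc1cc(OC[C@H](C)COc2ccc(C(=O)CC(C)(C)C)c(O)c2C)ccc1C(=O)O` differs from compound 3 by methoxy in place of fluoro on an aromatic carbon. Going by the values given here, no measured step exchanges fluoro for methoxy; the measured steps on this ring, a halogen swap and two position swaps, all stayed within the scatter, which is the only guide here. A step within the scatter is therefore expected, a 1.1-fold higher number from compound 3 to compound 4 (0.04 log units; within the scatter), with no direction asserted. For compound 4 the estimate in this assay is 1200 nM, expected between 450 nM and 3200 nM.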

Compound 4, half-maximal effective concentration: 1460 nM
Compound 4: middle estimate off by 1.2-fold (0.09 log units), on the low side; the measured number falls inside the stated range.
By their numbers in this assay, from the lowest: compounds 3, 1, 4 and 2 (each within the scatter of the next).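

In this assay, methoxy in place of fluoro, ortho to a carboxy group and meta to a large group, gives a 1.3-fold higher number from compound 3 to compound 4 (0.13 log units; within the scatter). Going by these compounds alone, this is the first change on this ring that goes beyond halogens and position swaps: a group of two heavy atoms, counted with a hydrogen-bond acceptor, replaces a single fluorine, and the number stays within the scatter. At this place, then, the read-out does not separate fluoro from methoxy, though a single pair cannot show more than that.

No supporting data bear on this step, so the result stands without an explanation. Still open, going by these compounds, is whether a larger ether such as benzyloxy, or an amine or a nitrile at this place, would also stay within the scatter.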